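The compounds below may be only part of what the source reports. "The series", "measured", "known", "first", "only" and "open" are said of these compounds alone.

Compound 3 `CC(=O)Nc1nc(-c2cccc(NS(=O)(=O)c3ccc(C#C[Si](C)(C)C)cc3)c2)cs1` stands lowest of the three numbers measured in a functional assay on A-375 cells (Homo sapiens) for antiproliferative activity, read by trypan blue exclusion, with a stated time of 48 h, tested at 5 uM (on this read-out higher numbers stand for a weaker effect at the one concentration tested and lower numbers for a stronger effect), where compound 3 gives 4.2%. Its nearest neighbour is compound 2 `CCCCC#Cc1ccc(S(=O)(=O)Nc2cccc(-c3csc(NC(C)=O)n3)c2)cc1`, which gives 9.3%, and the furthest is compound 1 `CC(=O)Nc1nc(-c2cccc(NS(=O)(=O)c3ccc(Br)cc3)c2)cs1`, which gives 19.7%; the step of a number 5.1 percentage points lower from compound 2 to compound 3 (within the scatter) lies within the scatter, whereas a number 15.5 percentage points lower from compound 1 to compound 3 (beyond the scatter) lies beyond it. Compound 4 `CCCCCCCCC#Cc1ccc(S(=O)(=O)Nc2cccc(-c3csc(NC(C)=O)n3)c2)cc1` differs from compound 3 in one place: a group of 8 heavy atoms (8 carbon; no ring) in place of a group of 4 heavy atoms (3 carbon, 1 silicon; no ring), on a triple-bonded carbon. The measured step most like this change is a number 5.1 percentage points lower from compound 2 to compound 3 (within the scatter), in which one chain was exchanged for another on the triple-bonded carbon without a shift beyond the scatter. On that basis no step beyond the scatter is expected in this assay, and the estimated a number 2.8 percentage points higher from compound 3 to compound 4 (within the scatter) is small. Compound 4 is expected to give 7%, within 0% to 20%.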

Compound 4, a percentage reported as activity, at one concentration (the size of the read-out at that concentration, not a potency): 8.9%
For compound 4 the middle estimate is 1.9 percentage points below the measured one; low and high end bracket the measured number.
By their numbers in this assay, from the lowest: compounds 3, 4 and 2 (each within the scatter of the next); then compound 1.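

In this assay, octyl in place of the silicon-bearing group on the triple-bonded carbon gives a number 4.7 percentage points higher from compound 3 to compound 4 (within the scatter) and butyl added to the chain of compound 2 gives a number 0.4 percentage points lower from compound 2 to compound 4 (within the scatter) so lengthening the chain from hex-1-yn-1-yl to dec-1-yn-1-yl shows no difference beyond the scatter. Replacing bromo with dec-1-yn-1-yl still gives a number 10.8 percentage points lower from compound 1 to compound 4 (beyond the scatter) so the longer chain keeps the separation from compound 1. No evidence is available to explain these results. Still open, going by these compounds, is whether a longer chain, or one ending in an amine or a carboxylic acid, would stay within the scatter of compound 4.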